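A few compounds are considered here, and "the series" means these few. Any claim that something is new, unique, unknown or untested is made for them only; others in the source may bear on it.

Compounds measured so far:
compound 1 `COCCOC1CCN(c2nc(N)c3cc(OC)c(OC)cc3n2)CC1`, 2.12 nM
compound 2 `COc1cc2nc(N3CCC(OCC(C)OC)CC3)nc(N)c2cc1OC`, 1.41 nM
compound 3 `CCOC(C)(COC1CCN(c2nc(N)c3cc(OC)c(OC)cc3n2)CC1)c1ccccc1`, 0.15 nM

In an assay on brain for displacement of a labelled ligand from Adrenergic receptor alpha-1 (Rattus norvegicus) (a lower number here means a stronger inhibitor, a higher number a weaker inhibitor), compound 3 stands lowest of the three, and its distance from both neighbours is beyond the scatter: a 9.4-fold lower number from compound 2 to compound 3 (0.97 log units; beyond the scatter) and a 14-fold lower number from compound 1 to compound 3 (1.15 log units; beyond the scatter). Compound 4 `COc1cc2nc(N3CCC(OCC(C)(O)c4ccccc4)CC3)nc(N)c2cc1OC` differs from compound 3 by hydrogen in place of ethyl on an oxygen on a saturated carbon, that is, ethoxy to hydroxy. For the measured compounds named here, no measured step isolates this change. The steps of a 14-fold lower number from compound 1 to compound 3 (1.15 log units; beyond the scatter) and a 9.4-fold lower number from compound 2 to compound 3 (0.97 log units; beyond the scatter) brought in the ethoxy together with the phenyl, so the ethyl may carry part of that gain, while a 1.5-fold lower number from compound 1 to compound 2 (0.18 log units; within the scatter) says little here. Compound 4 is therefore expected to lose some strength, with a 2.7-fold higher number from compound 3 to compound 4 (0.43 log units; beyond the scatter), to an estimated 0.4 nM (range 0.12 nM to 1.5 nM).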

Compound 4, inhibition constant: 0.62 nM
Compound 4: middle estimate off by 1.6-fold (0.19 log units), on the low side, and the stated range covers the measured number.
By their numbers in this assay, from the lowest: compound 3; then compound 4; then compounds 2 and 1 (each within the scatter of the next).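

In this assay, the ethoxy to hydroxy change is now seen on its own, and losing the ethyl weakens binding (a 4.1-fold higher number from compound 3 to compound 4 (0.62 log units; beyond the scatter)). The 1-hydroxy-1-phenylethyl group still gives lower numbers than the chains without phenyl (a 2.3-fold lower number from compound 2 to compound 4 (0.36 log units; beyond the scatter); a 3.4-fold lower number from compound 1 to compound 4 (0.53 log units; beyond the scatter)), so the ethyl accounts for only part of the gain seen with compound 3. Nothing available explains these steps. The compounds shown leave open how a methyl or a longer chain such as propyl on this oxygen would compare with ethyl. They also leave open what an amine in place of the hydroxy would do.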